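The source may hold more compounds than are shown below. What is called first, only, known or untested is meant among the compounds shown, and "the series" means these compounds.

Working notes on the series.

Three compounds of the shared core carry a different aryl on the carbon with a double bond to nitrogen. Compound 1 `O=C(N/N=C/c1ccccc1)c1cccnc1Nc1cccc(C(F)(F)F)c1` gives 21.2% in a functional assay on the whole organism (strain Wistar) for inhibition, with Rattus norvegicus as the target, read by paw edema, with a stated time of 3 h, at a dose of 10 mg/kg by the intraperitoneal route; on this read-out lower numbers stand for less inhibition and higher numbers for more inhibition at the one dose given (going by the name of the read-out). Compound 2 `O=C(N/N=C/c1ccc(Cl)cc1)c1cccnc1Nc1cccc(C(F)(F)F)c1` gives 48.5% in this assay, and compound 3 `O=C(N/N=C/c1cccc(O)c1)c1cccnc1Nc1cccc(C(F)(F)F)c1` gives 49%. The step of a number 27.3 percentage points higher from compound 1 to compound 2 (beyond the scatter) and the step of a number 27.8 percentage points higher from compound 1 to compound 3 (beyond the scatter) are both modest and beyond the scatter, whereas the step of a number 0.5 percentage points higher from compound 2 to compound 3 (within the scatter) is within the scatter. Compound 3 therefore sits at the top of the three numbers, though only its gap to compound 1 is beyond the scatter; against compound 2 no order can be read.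

Compound 4 `O=C(N/N=C/c1ccncc1)c1cccnc1Nc1cccc(C(F)(F)F)c1` is not yet measured. Its difference from compound 3: pyridin-4-yl in place of 3-hydroxyphenyl on a carbon with a double bond to nitrogen. Going by the values given here, the only step that swaps one whole aryl for another on that carbon is the one from compound 2 to compound 3, and that one was within the scatter; the two steps from compound 1 show that an unsubstituted phenyl sits lower. Among the compounds with values here, no measured compound carries a pyridinyl, so the expectation can lean on nothing more than the three numbers already given. A step of a number 11 percentage points lower from compound 3 to compound 4 (beyond the scatter) in this assay is expected, small and possibly not beyond the scatter. Compound 4 is estimated at 38%, between 18% and 58%.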

Compound 4, a percentage reported as inhibition, in the whole organism at one dose (the size of the read-out at that dose, not a potency): 54.9%
The estimate for compound 4 lay 16.9 percentage points below the measured number; measured number inside the range.
By their numbers in this assay, from the lowest: compound 1; then compounds 2, 3 and 4 (each within the scatter of the next).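

Going by these compounds alone, at this position the aryl need not carry a substituent on a carbon-only ring: the step of a number 33.7 percentage points higher from compound 1 to compound 4 (beyond the scatter) is the only one here that swaps the phenyl for a ring with a hetero atom, and it matches in direction the two steps that added chloro and hydroxy to the phenyl. The hydrogen-bond donor of the 3-hydroxyphenyl is also not required at this position, since pyridin-4-yl, with no donor, gives a number 5.9 percentage points higher from compound 3 to compound 4 (within the scatter) and, against the 4-chlorophenyl, a number 6.4 percentage points higher from compound 2 to compound 4 (within the scatter) in this assay and so leaves compounds 2, 3 and 4 with no order among them. No measurement in hand bears on why these aryl groups differ from the plain phenyl.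

Open, as far as these compounds go, is whether a pyridin-3-yl, or an amine or a carboxylic acid on the phenyl, would stay level with compounds 2, 3 and 4 or move beyond the scatter from them. From the compounds shown here alone, these numbers each come from a single dose and a single time, so how the compounds would rank at other doses, and whether their shared level marks a limit for this position, also remains open.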